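The source may report more compounds than this note shows. Statements on the series, on what has been measured and on what is new or still open speak of the compounds shown alone.

Measured in a functional assay on HT-29 cells (Homo sapiens) for antiproliferative activity, read by MTT assay, with a stated time of 72 h; a higher number here means a weaker inhibitor, a lower number a stronger inhibitor:
Compound 1 `O=C(Nc1ccc(Oc2ccnc3[nH]ccc23)cc1)c1cc2cccnc2n(-c2ccc(F)cc2)c1=O`, 160 nM
Compound 2 `COc1ccc(-n2c(=O)c(C(=O)Nc3ccc(Oc4ccnc5[nH]ccc45)cc3)cc3cccnc32)cc1`, 1260 nM
Compound 3 `O=C(Nc1ccc(Oc2ccnc3[nH]ccc23)c(F)c1)c1cc2cccnc2n(-c2ccc(F)cc2)c1=O`, 36 nM

Compound 3 stands lowest of the three numbers. Its nearest neighbour is compound 1, separated by a 4.4-fold lower number from compound 1 to compound 3 (0.65 log units; beyond the scatter); compound 2 lies furthest from it, as the step of a 7.9-fold higher number from compound 1 to compound 2 (0.90 log units; beyond the scatter) places compound 2 well beyond compound 1.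

Compound 4 `O=C(Nc1ccc(Oc2ccnc3[nH]ccc23)c(F)c1)c1cc2cccnc2n(-c2ccc(F)c(Cl)c2)c1=O` has not yet been measured. It differs from compound 3 by chloro in place of hydrogen on an aromatic carbon. For the measured compounds named here, no measured step repeats this change. The step of a 7.9-fold higher number from compound 1 to compound 2 (0.90 log units; beyond the scatter) alters the substitution of the same aryl ring but swaps one group for another, so it does not read directly onto an added chloro. The step of a 4.4-fold lower number from compound 1 to compound 3 (0.65 log units; beyond the scatter) adds a halogen elsewhere in the molecule and reached the best number seen. Going by the values given here, with no close precedent, the expectation for compound 4 is a step of a 1.1-fold higher number from compound 3 to compound 4 (0.05 log units; within the scatter), most likely within the scatter of compound 3. Compound 4 is therefore estimated at 40 nM, with a range from 15 nM to 120 nM.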

Compound 4, half-maximal inhibitory concentration: 310 nM
The estimate for compound 4 lay 7.8-fold (0.89 log units) below the measured number, outside the stated range (above it).
By their numbers in this assay, from the lowest: compound 3; then compounds 1 and 4 (each within the scatter of the next); then compound 2.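

In this assay, going from 4-fluorophenyl to 3-chloro-4-fluorophenyl gives an 8.6-fold higher number from compound 3 to compound 4 (0.94 log units; beyond the scatter), so this ring position, ortho to a fluoro group, does not accept a chloro without a loss of activity. The earlier step on this ring, a 7.9-fold higher number from compound 1 to compound 2 (0.90 log units; beyond the scatter), replaced the fluoro with methoxy, whereas here the fluoro stays and the number still rises; both changes shown on this ring therefore weaken activity, and none shown goes against this. No measurement shown bears on the cause of the new step.

From the compounds shown here alone, it remains open whether a methyl or a nitrile in place of the chloro would raise the number as well. Also open, going by these compounds, is whether the same chloro gives a step of this size on compound 1, which lacks the added fluoro of compound 3.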